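Trifluoromethoxy for trifluoromethyl in a glucagon receptor series

A few compounds are considered here, and "the series" means these few. Any claim that something is new, unique, unknown or untested is made for them only; others in the source may bear on it.

Compound 1 `O=C(O)CCNC(=O)c1ccc(CN(c2ccc(Cl)cc2)c2nc(-c3ccc(C(F)(F)F)cc3)cs2)cc1`: 76 nM
Compound 2 `Cc1cc(N(Cc2ccc(C(=O)NCCC(=O)O)cc2)c2nc(-c3ccc(C(F)(F)F)cc3)cs2)ccc1C(C)C`: 119 nM
Compound 3 `O=C(O)CCNC(=O)c1ccc(CN(c2ccc(OC(F)(F)F)cc2)c2nc(-c3ccc(C(F)(F)F)cc3)cs2)cc1`: 92 nM

Three compounds were measured in an in vitro assay on BHK cells for displacement of a labelled ligand from Glucagon receptor (Homo sapiens), read by scintillation proximity assay; on this read-out lower numbers stand for stronger inhibition and higher numbers for weaker inhibition. Compound 1 gives the lowest of the three numbers, but its gaps to compound 3 and compound 2 both lie within the scatter, so no order among them can be claimed. Compound 4 `O=C(O)CCNC(=O)c1ccc(CN(c2ccc(Cl)cc2)c2nc(-c3ccc(OC(F)(F)F)cc3)cs2)cc1` has not been measured. It differs from compound 1 in one place: trifluoromethoxy in place of trifluoromethyl on an aromatic carbon. Within the data shown here, none of the measured steps touches this position. The step of a 1.2-fold higher number from compound 1 to compound 3 (0.08 log units; within the scatter) put trifluoromethoxy in place of chloro on a different aromatic ring and stayed within the scatter, as did a 1.6-fold higher number from compound 1 to compound 2 (0.19 log units; within the scatter) and a 1.3-fold lower number from compound 2 to compound 3 (0.11 log units; within the scatter). Among the measured compounds shown here, the nearest precedent therefore gives no sign of a shift, and compound 4 is expected to show no step beyond the scatter: a 1.2-fold higher number from compound 1 to compound 4 (0.07 log units; within the scatter). The estimated value of compound 4 is 90 nM, with a range from 40 nM to 200 nM.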

Compound 4, half-maximal inhibitory concentration: 82 nM
For compound 4 the middle estimate is 1.1-fold (0.04 log units) above the measured one; low and high end bracket the measured number.
By their numbers in this assay, from the lowest: compounds 1, 4, 3 and 2 (each within the scatter of the next).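

Among these compounds, compound 4 gives the first reading at this position, with 4-(trifluoromethoxy)phenyl in place of 4-(trifluoromethyl)phenyl, and in this assay the result is a 1.1-fold higher number from compound 1 to compound 4 (0.03 log units; within the scatter). The change adds one oxygen and one hydrogen-bond acceptor by count, yet the step stays within the scatter, so this position accepts this exchange in the setting of compound 1. Nothing available explains this result.

The compounds shown leave open how an amine or a nitrile would read on this aromatic carbon. They also leave open whether the exchange gives a similar step alongside the other nitrogen substituent of compound 2 or compound 3.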